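A few compounds are considered here, and "the series" means these few. Any claim that something is new, unique, unknown or untested is made for them only; others in the source may bear on it.

Three compounds have numbers in an assay on isolated protein for inhibition of Rho-associated protein kinase 1 (Homo sapiens), read by scintillation counting, radiometric assay and 33P incorporation, with a stated time of 40 min, in the presence of a further agent that is not named here; on this read-out lower numbers stand for stronger inhibition and higher numbers for weaker inhibition. Compound 1 `COc1ccc(OCC(=O)Nc2cccc(NC(=O)c3ccc(N(C)C)cc3)c2)cc1F` gives 1820 nM. Compound 2 `CN(C)c1ccc(C(=O)Nc2cccc(NC(=O)COc3ccc4c(c3)OCCO4)c2)cc1` reaches only a limit of the measurement, > 10000 nM. The step of an at least 5.4-fold higher number from compound 1 to compound 2 (0.73 log units; beyond the scatter) is therefore read only as far as the limit of > 10000 nM in this assay, at which 1 of the 3 values shown sits, allows. Compound 3 `CC(C)(C)c1ccc(C(=O)Nc2cccc(NC(=O)COc3ccc4c(=O)ccoc4c3)c2)cc1` gives 165 nM, the lowest of the two numbers shown, with compound 1 the nearer and higher of the two.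

Compound 4 `COC(=O)c1ccc(C(=O)Nc2cccc(NC(=O)COc3ccc4c(=O)ccoc4c3)c2)cc1` is drawn from compound 3 by methoxycarbonyl in place of tert-butyl on an aromatic carbon. Going by the values given here, the one measured step, from compound 1 to compound 2, concerns a group on the oxygen on a saturated carbon at the other end of the shared core, so it does not bear on a change at the six-membered aromatic ring of carbon only, and no measured step does. With no guide to the direction, the change is expected to give compound 4 a step of a 2.4-fold higher number from compound 3 to compound 4 (0.38 log units; beyond the scatter) in this assay, a modest rise. Compound 4 is accordingly estimated at 400 nM, within 120 nM to 1500 nM.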

Compound 4, half-maximal inhibitory concentration: 72 nM
For compound 4 the middle estimate is 5.6-fold (0.74 log units) above the measured one; the measured number lies below the stated range.
By their numbers in this assay, from the lowest: compound 4; then compound 3; then compound 1. At a limit, above all of these: compound 2.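

Going by these compounds alone, with methoxycarbonyl in place of tert-butyl on an aromatic carbon, para to a large group, this assay records a 2.3-fold lower number from compound 3 to compound 4 (0.36 log units; beyond the scatter) and gives the first measured reading at this position. The step is modest but beyond the scatter, and it shows that the number here does not depend on tert-butyl: a group with the same heavy-atom count, but with oxygen and hydrogen-bond acceptors in it, gives no loss. Nothing measured among these compounds explains the change.

With a single step at this position, the compounds shown do not say whether a carboxylic acid, a primary amide or a nitrile in the same place would move the number further down or back up. They also leave open whether an amine or a longer ester chain would be accepted there.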